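The compounds below may be only part of what the source reports. "The series", "measured", "known", "first", "only" and "open" are said of these compounds alone.

Of the compounds shown here, two sharing one core have so far been measured in an in vitro assay on cells for inhibition of Amine oxidase [flavin-containing] B (Homo sapiens), read by fluorescence and Amplex Red, with stated times of 30 min and 45 min; on this read-out lower numbers stand for stronger inhibition and higher numbers for weaker inhibition. Compound 1 `COc1cccc(CCC(=O)Nc2nc3ccccc3c(=O)s2)c1` gives 95.3 nM in this assay. Compound 2 `O=C(CCc1ccccc1Br)Nc1nc2ccccc2c(=O)s1` gives 2.09 nM in this assay. For the measured compounds named here, the single step between them, a 46-fold lower number from compound 1 to compound 2 (1.66 log units; beyond the scatter), came with 2-bromophenyl in place of 3-methoxyphenyl on a saturated chain carbon, two bonds along the chain from a carbonyl carbon. Compound 2 therefore holds the lowest of the two numbers shown, with compound 1 its only neighbour and a long way above it.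

Compound 3 `O=C(CCc1ccc(Cl)c(Cl)c1)Nc1nc2ccccc2c(=O)s1` has not yet been measured in this assay. It differs from compound 2 in one place: 3,4-dichlorophenyl in place of 2-bromophenyl on a saturated chain carbon, two bonds along the chain from a carbonyl carbon. Going by the values given here, the only measured step that bears on this change is the one from compound 1 to compound 2, which also swapped one substituted phenyl for another at that place and was large. Among the compounds with values here, no step shows whether a second swap of this kind keeps the number of compound 2. The step to compound 3 is expected to be a 4.8-fold higher number from compound 2 to compound 3 (0.68 log units; beyond the scatter), toward weaker inhibition. The estimate for compound 3 in this assay is 10 nM, within a range from 2 nM to 60 nM.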

Compound 3, half-maximal inhibitory concentration: > 10000 nM
Compound 3 was reported as a limit; the forecaster's own chance of this, stated with the estimate: 2%; at least 1000-fold (3.00 log units) between middle value and limit.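

In this assay, compound 3 is reported only as a limit and not as a number: the limit of > 10000 nM in this assay, at which 1 of the 3 values shown sits.

The earlier step showed that a change of substituted phenyl on this saturated chain carbon, two bonds along the chain from a carbonyl carbon, could strengthen inhibition; this result shows that such a change can also nearly abolish it within the tested range, since putting 3,4-dichlorophenyl in place of 2-bromophenyl gives an at least 4700-fold higher number from compound 2 to compound 3 (3.67 log units; beyond the scatter). The same group also compares poorly with 3-methoxyphenyl, the weaker of the two earlier groups, with an at least 100-fold higher number from compound 1 to compound 3 (2.02 log units; beyond the scatter). The place therefore tolerates some substituted phenyl groups but not all of them, and the gain seen with 2-bromophenyl does not carry over to every halogen-bearing phenyl group among these three compounds.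

The three compounds do not separate the effect of the halogen's identity from that of its place on the ring, nor the effect of one chlorine from that of two, and 2-chlorophenyl, 4-chlorophenyl and unsubstituted phenyl would each bear on this. They also leave open whether a longer chain at this place would change the response to 3,4-dichlorophenyl.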